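Swapping Chloro for Cyano on a Benzyl Ether

A few compounds are considered here, and "the series" means these few. Any claim that something is new, unique, unknown or untested is made for them only; others in the source may bear on it.

Measured so far:
compound 1 `O=C1CSc2cc(OCc3ccccc3)ccc2N1` with 8060 nM
compound 2 `O=C1CSc2cc(OCCCc3ccccc3)ccc2N1` with 96800 nM
compound 3 `O=C1CSc2cc(OCc3ccc(Cl)cc3)ccc2N1` with 24400 nM

All three share one core and differ only in the group hanging off its ether oxygen. In an assay on isolated protein for inhibition of Amine oxidase [flavin-containing] A (Homo sapiens), read by fluorescence and spectrophotometry, with a stated time of 20 min (on this read-out higher numbers stand for weaker inhibition and lower numbers for stronger inhibition), compound 1 gives 8060 nM, the lowest number of the three. Compound 2, carrying a longer chain, gives 96800 nM, the highest. Compound 3 stands second highest; its nearest neighbour is compound 1, and the step of a 3.0-fold higher number from compound 1 to compound 3 (0.48 log units; beyond the scatter) is a modest loss that lies beyond the usual scatter. Compound 2 gives a higher number than compound 3.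

Compound 4 `N#Cc1ccc(COc2ccc3c(c2)SCC(=O)N3)cc1` differs from compound 3 in one place: cyano in place of chloro on an aromatic carbon. Within the data shown here, only one measured step bears on it, a 3.0-fold higher number from compound 1 to compound 3 (0.48 log units; beyond the scatter), which shows that placing chloro where hydrogen stood cost a modest amount. Among the measured compounds shown here, no measured compound carries a cyano, so the size of this swap is uncertain. A cyano is expected to behave somewhat like chloro, with a step of a 1.2-fold lower number from compound 3 to compound 4 (0.09 log units; within the scatter) that stays within or near the scatter. Compound 4 is therefore estimated at 20000 nM, in the range from 6000 nM to 65000 nM, in this assay.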

Compound 4, half-maximal inhibitory concentration: 714 nM
The estimate for compound 4 lay 28-fold (1.45 log units) above the measured number; the measured number lies below the stated range.
By their numbers in this assay, from the lowest: compound 4; then compound 1; then compound 3; then compound 2.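

In this assay, the position para to a large group on the aromatic ring proves far more sensitive than the chloro step alone suggested. Here the direction of change depends on the group: chloro raised the number, whereas cyano in place of hydrogen gives an 11-fold lower number from compound 1 to compound 4 (1.05 log units; beyond the scatter), and cyano in place of chloro gives a 34-fold lower number from compound 3 to compound 4 (1.53 log units; beyond the scatter). Chloro and cyano therefore cannot be treated as interchangeable at this position, and no supporting measurement is available to explain the gap between them.

The compounds shown leave open whether other groups here, such as a methoxy group, an amine or a carboxylic acid, would follow cyano or chloro. They also leave open whether cyano would lower the number in the same way on the longer chain of compound 2.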